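Swapping One Five-Membered Ring on the Shared Core

This account rests on a few compounds, and the source may have more. Where it says the series, first, only, none or still open, it means among the compounds named here.

Going by the values given here, compound 1 `O=C1Nc2ccc(N3CCOC3=O)cc2C(CNC(=O)c2ccc(F)cc2)(C(F)(F)F)O1` is the only compound with a number in an assay for inhibition of very long chain fatty acid elongase 6 (Homo sapiens) (a higher number here means a weaker inhibitor, a lower number a stronger inhibitor), where compound 1 gives 67 nM. Compound 2 `O=C1Nc2ccc(Cl)cc2C(CNC(=O)c2ccc(-c3ccccc3)cc2)(C(F)(F)F)O1` reaches only a limit in this assay, > 10000 nM, and that limit is one of the two values shown (the limit of > 10000 nM in this assay, at which 1 of the 2 values shown sits). Compound 3 `O=C1Nc2ccc(-c3ccon3)cc2C(CNC(=O)c2ccc(F)cc2)(C(F)(F)F)O1` keeps the core of compound 1 with one change: 1,2-oxazol-3-yl in place of 2-oxo-1,3-oxazolidin-3-yl on an aromatic carbon. Among the compounds with values here, no measured pair shows such a step, so the expected step is a 1.5-fold higher number from compound 1 to compound 3 (0.17 log units; within the scatter), no larger than the scatter. Compound 3 is estimated at 100 nM, expected between 30 nM and 400 nM.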

Compound 3, half-maximal inhibitory concentration: 121 nM
For compound 3 the middle estimate is 1.2-fold (0.08 log units) below the measured one, and the stated range covers the measured number.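

On this aromatic carbon, the non-aromatic 2-oxo-1,3-oxazolidin-3-yl and the aromatic 1,2-oxazol-3-yl cannot be told apart: in this assay the swap gives a 1.8-fold higher number from compound 1 to compound 3 (0.26 log units; within the scatter). For this pair, then, the carbonyl of the ring that leaves is not needed for a number in this range, and either five-membered ring fits at this position. As far as these compounds go, whether an amine, a carboxylic acid or a six-membered morpholine ring would also be tolerated here stays open. Nothing among the data shown explains why these two rings read so alike.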